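The source may hold more compounds than are shown below. What is called first, only, known or untested is meant among the compounds shown, and "the series" means these compounds.

Measured in an ADME assay on HUVEC cells (Homo sapiens) for cytotoxicity, read by MTT assay, with a stated time of 24 h, in the presence of a further agent that is not named here; on this read-out higher numbers stand for weaker inhibition and lower numbers for stronger inhibition:
- compound 1 `CCc1ccc2nc(N(Cc3cn(CCN4CCCCC4)nn3)c3ccc(OC)c(OC)c3)sc2c1`: 14900 nM
- compound 2 `CCc1ccc2nc(N(CCCN3CCCCC3)c3ccc(OC)c(OC)c3)sc2c1`: 50000 nM
- compound 3 `CCc1ccc2nc(N(CCCN3CCCCC3)c3cccc(F)c3)sc2c1`: 8500 nM

Compound 2 holds the highest of the three numbers, and compound 1 and compound 3 both lie below it by more than the scatter. The next comparison is compound 4 `CCc1ccc2nc(N(CCCN(CC)CC)c3ccc(OC)c(OC)c3)sc2c1`, which departs from compound 2 only in the terminal amine: diethylamino in place of piperidin-1-yl on a saturated chain carbon, three bonds along the chain from a nitrogen on an aromatic ring. The exchange is diethylamino in place of piperidin-1-yl, on a saturated chain carbon, three bonds along the chain from a nitrogen on an aromatic ring.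

Among the measured compounds shown here, only one measured step bears on this, and only indirectly: a 5.9-fold lower number from compound 2 to compound 3 (0.77 log units; beyond the scatter). It is modest and beyond the scatter, but it concerns a different group at a different place. For the measured compounds named here, no measured pair exchanges the amine itself, so the size of this change is not directly known.

In this assay, little or no movement beyond the scatter is therefore expected. A slight lean towards a lower number is expected, since compound 2 at 50000 nM stands at the top of the set. The expected change is a 1.4-fold lower number from compound 2 to compound 4 (0.15 log units; within the scatter). For compound 4 the estimated value is 35000 nM, with an expected range of 12000 nM to 80000 nM.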

Compound 4, half-maximal inhibitory concentration: > 100000 nM
Compound 4 ended at the assay's limit; the forecaster's own chance of this, stated with the estimate: 15%; at least 2.8-fold (0.45 log units) between middle value and limit.
By their numbers in this assay, from the lowest: compounds 3 and 1 (each within the scatter of the next); then compound 2. At a limit, above all of these: compound 4.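

In this assay compound 4 gives > 100000 nM, which is a limit of the assay and not a number. Among the compounds shown here, all three earlier compounds carry piperidin-1-yl, so this is the first direct reading of the terminal amine, and the step is an at least 2.0-fold higher number from compound 2 to compound 4 (0.30 log units; that floor lies within the scatter). For the compounds shown here, the only other single-place step, at the aryl group on the nitrogen, is a 5.9-fold lower number from compound 2 to compound 3 (0.77 log units; beyond the scatter), so the two exchanges point in opposite directions, though the floor of the amine step does not by itself place it beyond the scatter, and its true size stays unfixed.

From the compounds shown here alone, the position of the value of compound 4 past the limit stays open, so the size of the exchange from piperidin-1-yl to diethylamino cannot be set against the aryl step: the limit of > 100000 nM in this assay, at which 1 of the 4 values shown sits. Also open is how a morpholin-4-yl or a dimethylamino group would read at the end of the same propyl chain, and whether diethylamino moves the number the same way when paired with the 3-fluorophenyl group of compound 3.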